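Methoxy to Hydroxy Where Every Value Is a Limit

The source may hold more compounds than are shown below. What is called first, only, known or untested is meant among the compounds shown, and "the series" means these compounds.

Compound 3 `COc1cc(-c2nn(-c3cccc(NC(=O)Nc4ccc(Cl)c(C(F)(F)F)c4)c3)cc2-c2ccncc2)ccc1Cl` stands at the ceiling of what this study measured. In a functional assay on SNB-75 cells (Homo sapiens) for inhibition, read by sulforhodamine B assay, with a stated time of 48 h (on this read-out lower numbers stand for higher toxicity in this test and higher numbers for lower toxicity in this test), compound 3 gives > 32500 nM, which is a limit of the assay and not a number. Compound 1 `O=C(Nc1cccc(-n2cc(-c3ccncc3)c(-c3ccc(Cl)c(O)c3)n2)c1)Nc1cccc(C(F)(F)F)c1` is a hydroxy analogue with a different urea aryl group. In this assay compound 1 gives > 32500 nM, again a limit. Compound 2 `O=C(Nc1cccc(-n2cc(-c3ccncc3)c(-c3ccc(Cl)c(O)c3)n2)c1)Nc1ccc(Cl)c(Cl)c1` carries 3,4-dichlorophenyl in place of 3-(trifluoromethyl)phenyl on an amide-type nitrogen. In this assay compound 2 gives > 32500 nM, also a limit. The step that the two limits leave unreadable from compound 1 to compound 2 is accordingly unreadable. Compound 4 `O=C(Nc1cccc(-n2cc(-c3ccncc3)c(-c3ccc(Cl)c(O)c3)n2)c1)Nc1ccc(Cl)c(C(F)(F)F)c1` differs from compound 3 by hydrogen in place of methyl on an oxygen on an aromatic ring. Among the measured compounds shown here, no measured step follows this exact change, yet every value shown sits at the same point the limit of > 32500 nM in this assay, at which 3 of the 3 values shown sit: compounds 1 and 2 share the hydroxy group of compound 4, and compound 3 shares its urea aryl group. A step that the limit leaves unreadable from compound 3 to compound 4 is therefore expected, with no change beyond the scatter. Compound 4 is expected to give 50000 nM, within 20000 nM to 200000 nM, most probably reported once more as a limit.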

Compound 4, concentration lethal to 50% of the cells: > 32500 nM
Compound 4: only a limit was reported; the forecaster's own chance of this, stated with the estimate: 85%; the middle value is on the limit's open side.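

None of the steps from compound 1, compound 2 or compound 3 to compound 4 can be read: all four results are limits of the assay, not numbers. Left open is how toxic any of these compounds is in this assay and whether the change from methoxy to hydroxy alters that at all.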